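A few compounds are considered here, and "the series" means these few. Any claim that something is new, unique, unknown or untested is made for them only; others in the source may bear on it.

Working notes on the series. Compound 3 `CN1CCN(c2ccc(Nc3ncc4c(n3)N(C3CCCC3)CC(=O)N4C)cc2)CC1` in an ADME assay on HEK293 cells (Homo sapiens) for inhibition, read by MTT assay, with a stated time of 48 h (a higher number here means a weaker inhibitor, a lower number a stronger inhibitor), gives 12400 nM, the lowest of the two numbers in hand. Among the measured compounds shown here, compound 2 `O=C1CN(C2CCCC2)c2nc(Nc3ccc(N4CCCCC4)cc3)ncc2N1` gives 25100 nM, and the gap between that number and the one for compound 3 lies beyond the scatter. For compound 1 `CN1CCN(c2ccc(Nc3ncc4c(n3)N(C3CCCC3)CC(=O)N4)cc2)CC1` this assay reports only a limit, > 30000 nM, (the limit of > 30000 nM in this assay, at which 1 of the 3 values shown sits).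

Compound 4 `CN1C(=O)CN(C2CCCC2)c2nc(Nc3ccc(N4CCCCC4)cc3)ncc21`, still to be measured, differs from compound 3 in one place: piperidin-1-yl in place of 4-methylpiperazin-1-yl on an aromatic carbon. Relative to compound 1 it carries both the ring swap and the methyl on the ring nitrogen.

For the measured compounds named here, two measured steps bear on this. The same ring swap is seen once, an at least 1.1-fold lower number from compound 1 to compound 2 (0.07 log units; that floor lies within the scatter); since the starting value there is a limit, that step has a floor but no fixed size. The methyl step, an at least 2.4-fold lower number from compound 1 to compound 3 (0.38 log units; beyond the scatter), is already built into compound 3 and does not enter the present comparison. The step expected in this assay is therefore a 1.4-fold lower number from compound 3 to compound 4 (0.14 log units; within the scatter), small, no larger than the scatter, and if anything toward a lower number.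

Compound 4 is estimated at 9000 nM in this assay, within 3500 nM to 25000 nM.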

Compound 4, half-maximal inhibitory concentration: 25300 nM
For compound 4 the middle estimate is 2.8-fold (0.45 log units) below the measured one; measured number outside the range, above it.
By their numbers in this assay, from the lowest: compound 3; then compounds 2 and 4 (each within the scatter of the next). At a limit, above all of these: compound 1.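

With the methyl already on the ring nitrogen, piperidin-1-yl in place of 4-methylpiperazin-1-yl on the aromatic carbon now gives a step of fixed size in this assay, a 2.0-fold higher number from compound 3 to compound 4 (0.31 log units; beyond the scatter), and its direction is toward a higher number, which the earlier floor could not show: the same change on two cores in this assay, an at least 1.1-fold lower number (0.07 log units; that floor lies within the scatter) from compound 1 to compound 2 and a 2.0-fold higher number (0.31 log units; beyond the scatter) from compound 3 to compound 4; the limit leaves it open whether they differ

The methyl step can also now be read between two numbers, a 1.0-fold higher number from compound 2 to compound 4 (0.00 log units; within the scatter), so on the core with piperidin-1-yl the methyl brings no change beyond the scatter: the same change on two cores in this assay, an at least 2.4-fold lower number (0.38 log units; beyond the scatter) from compound 1 to compound 3 and a 1.0-fold higher number (0.00 log units; within the scatter) from compound 2 to compound 4; the limit leaves it open whether they differ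

Among the compounds that carry the methyl, the lower number belongs to compound 3 at 12400 nM, so within this pair the 4-methylpiperazin-1-yl group, not piperidin-1-yl, goes with the lower number.

From the compounds shown here alone, compound 1 gives only a limit, > 30000 nM, so it stays open whether either change depends on the other. Also open, going by these compounds, is how a morpholin-4-yl group, a piperazin-1-yl group with a free ring amine, or a carboxylic acid on that aromatic carbon would read, and how an ethyl in place of the methyl on the ring nitrogen would read.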